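Taking one methoxy from compound 2

The source may hold more compounds than are shown below. What is called first, only, known or untested is meant among the compounds shown, and "the series" means these compounds.

Values in a functional assay on A549 cells (Homo sapiens) for cytotoxicity, read by MTT assay, with a stated time of 72 h (on this read-out higher numbers stand for weaker inhibition and lower numbers for stronger inhibition), stand as follows:
compound 1 `COc1cccc(/C=C2\CCC/C(=C\c3cccc(OC)c3OC)C2=O)c1` gives 16400 nM
compound 2 `COc1ccc(/C=C2\CCC/C(=C\c3cccc(OC)c3OC)C2=O)cc1OC` gives 14400 nM
compound 3 `COc1cccc(/C=C2\CCC/C(=C\c3cc(OC)c(OC)c(OC)c3)C2=O)c1OC` gives 5900 nM

Compound 2 sits level with compound 1 within the scatter, and its number is higher than that of compound 3. Compound 4 `COc1cccc(/C=C2\CCC/C(=C\c3ccc(OC)c(OC)c3)C2=O)c1` differs from compound 2 by hydrogen in place of methoxy on an aromatic carbon, ortho to a large group and ortho to a methoxy group (hydrogen in place of methoxy on an aromatic carbon). Two measured steps run the opposite way, methoxy in place of hydrogen on an aromatic carbon, though neither at this carbon (a 1.1-fold lower number from compound 1 to compound 2 (0.06 log units; within the scatter)) (a 2.4-fold lower number from compound 2 to compound 3 (0.39 log units; beyond the scatter)). The first lies within the scatter and the second is modest, so only a small rise or none is expected in this assay here. The expected change is a 1.2-fold higher number from compound 2 to compound 4 (0.07 log units; within the scatter) and is estimated to lie within the scatter. For compound 4 the estimated value is 17000 nM (range 8000 nM to 35000 nM).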

Compound 4, half-maximal inhibitory concentration: 6700 nM
Estimate against measurement, compound 4: 2.5-fold (0.40 log units) above; the whole stated range lies above it.
By their numbers in this assay, from the lowest: compounds 3 and 4 (each within the scatter of the next); then compounds 2 and 1 (each within the scatter of the next).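

In this assay, hydrogen in place of methoxy on the aromatic carbon ortho to a large group and ortho to a methoxy group gives a 2.1-fold lower number from compound 2 to compound 4 (0.33 log units; beyond the scatter) as a modest step. The earlier step of a 2.4-fold lower number from compound 2 to compound 3 (0.39 log units; beyond the scatter) added a methoxy at another carbon and also lowered the number, so the count of methoxy groups alone does not set the value in this pair of steps. Nothing measured here accounts for this. The compounds shown leave open whether a hydroxyl or an ethoxy group on this carbon would read like hydrogen or like methoxy. They also leave open whether the change holds on other cell lines.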